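Series notes: amide-nitrogen substitution, first estimate

The compounds below may be only part of what the source reports. "The series", "measured", "known", "first", "only" and "open" are said of these compounds alone.

Measured so far:
- compound 1 `O=C1NC(=O)/C(=C/c2cn(-c3ccccc3)nc2-c2ccccc2)S1`: "not evaluated" (no result reported)
- compound 2 `O=C1NC(=O)/C(=C/c2cn(-c3ccccc3)nc2-c2ccc(Cl)cc2)S1`: "not evaluated" (no result reported)
- compound 3 `C=CCN1C(=O)S/C(=C\c2cn(-c3ccccc3)nc2-c2ccc(Cl)cc2)C1=O`: 10000 nM

In a functional assay on SH-SY5Y cells (Homo sapiens) for inhibition, with stated times of 48 h and 72 h (a lower number here means a stronger inhibitor, a higher number a weaker inhibitor), compound 1 has no single number, and compound 2 likewise stands without a result. For the measured compounds named here, the only value in this assay comes from compound 3, which gives 10000 nM, a weak result with the allyl group on the ring nitrogen. Compound 4 `O=C1S/C(=C\c2cn(-c3ccccc3)nc2-c2ccccc2)C(=O)N1Cc1ccc(Cl)cc1` differs from compound 1 by 4-chlorobenzyl in place of hydrogen on an amide-type nitrogen in a ring. Going by the values given here, no step between measured compounds exists, so no size of step can be read from the numbers; the expectation is that compound 4 lands in the same weak region as compound 3, with no direction beyond the scatter claimed. Compound 4 is estimated at 10000 nM (range 2000 nM to 50000 nM).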

Compound 4, half-maximal inhibitory concentration: 80000 nM
Beside the measured number, compound 4's estimate is 8.0-fold (0.90 log units) below it, outside the stated range (above it).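

In this assay no new step can be read from compound 1 to compound 4, since compound 1 holds no single number. The compounds shown leave open what 4-chlorobenzyl in place of the amide hydrogen does to inhibition. No evidence bears on this result.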